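Threonine amides: sulfonylation of the amine nitrogen

The source may report more compounds than this note shows. Statements on the series, on what has been measured and on what is new or still open speak of the compounds shown alone.

Compound 1 `CCCCCCCCCCCCCCCCCCNC(=O)[C@@H](N)[C@@H](C)O` carries a free amine on the threonine unit with an octadecyl amide; in a functional assay on SW-620 cells (Homo sapiens) for cytotoxicity, read by MTT assay, with a stated time of 48 h (a higher number here means a weaker inhibitor, a lower number a stronger inhibitor), compound 1 gives 21400 nM. Compound 2 `CCCCCCCCCCCCNC(=O)[C@@H](NC(=O)c1cc2ccccc2o1)[C@@H](C)O` differs in both chain and amine substituent and in this assay compound 2 gives 21300 nM, so the two numbers lie within the scatter of each other and neither stands apart. Compound 3 `CCCCCCCCCCCCCCCCCCNC(=O)[C@@H](NS(=O)(=O)c1cccs1)[C@@H](C)O` keeps the octadecyl chain of compound 1 and differs only by (thiophen-2-yl)sulfonyl in place of hydrogen on an amine nitrogen. Given that compound 2 with an acylated nitrogen gives 21300 nM, no step beyond the scatter is expected from compound 1 to compound 3, a 1.1-fold lower number from compound 1 to compound 3 (0.03 log units; within the scatter). Compound 3 is estimated at 20000 nM, between 7000 nM and 60000 nM.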

Compound 3, half-maximal inhibitory concentration: > 200000 nM
Compound 3: no number, only a limit; the forecaster's own chance of this, stated with the estimate: 15%; at least 10-fold (1.00 log units) between middle value and limit.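

On the amine nitrogen of the octadecyl threonine amide, (thiophen-2-yl)sulfonyl in place of hydrogen does not leave the read-out in this assay unchanged, giving an at least 9.3-fold higher number from compound 1 to compound 3 (0.97 log units; beyond the scatter). For the compounds shown here, compound 1 and compound 2 differ in two places, so this is the first single change at this nitrogen that can be read. Compound 3 stands only at a limit of the assay, not at a number: the limit of > 200000 nM in this assay, at which 1 of the 3 values shown sits.

Going by these compounds, whether a methylsulfonyl or phenylsulfonyl group on the same nitrogen gives a similar step remains open. So does whether the step holds with a shorter chain on the amide.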